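The source may report more compounds than this note shows. Statements on the series, on what has been measured and on what is new or still open speak of the compounds shown alone.

Compound 1, `CNC(=O)c1cc(F)ccc1CNC(=O)c1cc2nc(C)c([C@H](OC(C)(C)C)C(=O)O)c(-c3cc(F)c4c(c3C)CCCO4)n2n1`: > 40000 nM
Compound 2, `Cc1nc2cc(C(=O)NCc3ccc(F)cc3N3CCCC3=O)nn2c(-c2cc(F)c3c(c2C)CCCO3)c1[C@H](OC(C)(C)C)C(=O)O`: > 40000 nM
Compound 3, `Cc1nc2cc(C(=O)NCCC3CCCCC3)nn2c(-c2cc(F)c3c(c2C)CCCO3)c1[C@H](OC(C)(C)C)C(=O)O`: > 40000 nM

In an ADME assay on MT2 cells (Homo sapiens) for cytotoxicity (on this read-out higher numbers stand for lower toxicity in this test and lower numbers for higher toxicity in this test), compound 1 is reported only as a limit, not as a number. Compound 2 and compound 3 are likewise reported only as limits, so each of the steps a step that the two limits leave unreadable from compound 1 to compound 2 and a step that the two limits leave unreadable from compound 1 to compound 3 cannot be read, as all three values sit at the limit of > 40000 nM in this assay, at which 3 of the 3 values shown sit. Compound 4, `Cc1nc2cc(C(=O)NCC3CCOCC3)nn2c(-c2cc(F)c3c(c2C)CCCO3)c1[C@H](OC(C)(C)C)C(=O)O`, differs from compound 1 as follows: oxan-4-yl in place of 4-fluoro-2-(methylcarbamoyl)phenyl on a saturated chain carbon bound to an amide-type nitrogen. Neither measured step bears readably on this change, and no direction or size can be drawn from them. Compound 4 is therefore expected to be reported at the same limit, with an estimate of 40000 nM and a range from 20000 nM to 80000 nM. The expected step is a number no higher from compound 1 to compound 4 (the limit leaves the size open), none beyond the scatter.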

Compound 4, half-maximal cytotoxic concentration: > 40000 nM
Compound 4: a limit, no number; the forecaster's own chance of this, stated with the estimate: 85%; the middle value sits exactly at the limit.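

In this assay compound 4 is reported only as a limit, > 40000 nM, so the steps to compound 4 from compound 1 and compound 3 cannot be read. The compounds shown leave open whether these groups differ at all in this read-out, and at what concentration any of them becomes cytotoxic: the limit of > 40000 nM in this assay, at which 4 of the 4 values shown sit.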